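Fluoro to nitro on compound 2

This account rests on a few compounds, and the source may have more. Where it says the series, first, only, none or still open, it means among the compounds named here.

In an ADME assay on MCF7-DOX cells (Homo sapiens) for cytotoxicity, read by MTT assay, with a stated time of 48 h (on this read-out higher numbers stand for weaker inhibition and lower numbers for stronger inhibition), compound 1 `COc1cc(O)c(C(=O)/C=C/c2ccc(N3CCNCC3)cc2)c(OC)c1` gives 67500 nM and compound 3 `COc1cc(O)c(C(=O)/C=C/c2cccc(N3CCNCC3)c2)c(OC)c1` gives 99200 nM on the same read-out. Compound 2 `COc1cc(OC)c(C(=O)/C=C/c2cccc(F)c2)c(O)c1CC=C(C)C` reads 45400 nM and so stands within the scatter of compound 1 while lying beyond the scatter from compound 3, whose number is higher. Within the data shown here, no two of these three compounds differ in one place only, so no measured step is available as a guide.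

Compound 4 `COc1cc(OC)c(C(=O)/C=C/c2cccc([N+](=O)[O-])c2)c(O)c1CC=C(C)C` keeps the frame of compound 2 and carries nitro in place of fluoro on an aromatic carbon, meta to a large group nitro in place of fluoro on an aromatic carbon which reads as 3-fluorophenyl to 3-nitrophenyl. With nothing measured to suggest a direction, no shift beyond the scatter is expected in this assay. The estimate stays close to compound 2 at 45400 nM with a wide margin. The expected change is small, an estimated 1.1-fold lower number from compound 2 to compound 4 (0.03 log units; within the scatter) in either direction. Compound 4 is estimated at 42000 nM (expected range 17000 nM to 100000 nM).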

Compound 4, half-maximal inhibitory concentration: 57000 nM
Estimate against measurement, compound 4: 1.4-fold (0.13 log units) below, within the range that was stated.
By their numbers in this assay, from the lowest: compounds 2, 4, 1 and 3 (each within the scatter of the next, the first and the last beyond it).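

Among these compounds, the exchange gives the first step that can be read (a 1.3-fold higher number from compound 2 to compound 4 (0.10 log units; within the scatter)) in this assay, and it places the two compounds within the scatter of each other. On this aromatic carbon, meta to a large group, nitro with its 3 heavy atoms and 2 hydrogen-bond acceptors therefore reads no differently from fluoro, a single heavy atom with no acceptors. Nothing at hand offers an explanation for this outcome.

As far as these compounds go, whether an amine or a carboxylic acid on the same carbon would also stay within the scatter of compound 2 remains open. So does whether the 3-fluorophenyl to 3-nitrophenyl exchange would read the same on a frame without the prenyl-type chain of compound 2, since this single step rests on one frame.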